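Replacing 1H-imidazol-1-yl with 2,2,2-trifluoroethoxy

The source may hold more compounds than are shown below. What is called first, only, known or untested is meant among the compounds shown, and "the series" means these compounds.

- compound 1 `COC(=O)C1=C(CN2CCOCC2=O)NC(c2nccs2)=NC1(C)c1ccc(F)cc1` gives 440 ug/mL in solution
- compound 2 `COC(=O)C1=C(Cn2ccnc2)NC(c2nccs2)=NC1(C)c1ccc(F)cc1` gives 338 ug/mL in solution

Both values come from a physicochemical assay for solubility, read by HPLC, in phosphate buffer, at pH 6.5 (on this read-out higher numbers stand for higher solubility and lower numbers for lower solubility), and they lie within the usual scatter of each other, so compound 2 holds no clear rank against compound 1. Within the data shown here, the only measured step is a 1.3-fold lower number from compound 1 to compound 2 (0.11 log units; within the scatter) and it swapped one ring-bearing group for another at the same place.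

Compound 3 `COC(=O)C1=C(COCC(F)(F)F)NC(c2nccs2)=NC1(C)c1ccc(F)cc1` changes that place again, with 2,2,2-trifluoroethoxy in place of 1H-imidazol-1-yl on a saturated chain carbon bound to a double-bonded ring carbon. The entering group has no ring, so the measured step is only a loose guide. Among the measured compounds shown here, a lower number is expected on the structural change alone, and no measured step of this kind exists to confirm it. The expected change is a 2.8-fold lower number from compound 2 to compound 3 (0.45 log units; beyond the scatter) in this assay as a rough estimate. For compound 3 the estimate is 120 ug/mL with an expected range from 35 ug/mL to 350 ug/mL in this assay for now.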

Compound 3, solubility: 19 ug/mL
The estimate for compound 3 lay 6.3-fold (0.80 log units) above the measured number, outside the stated range (below it).
By their numbers in this assay, from the lowest: compound 3; then compounds 2 and 1 (each within the scatter of the next).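

In this assay, this position turns out to matter much more than the first swap suggested. The two ring-bearing groups, 3-oxomorpholin-4-yl and 1H-imidazol-1-yl, stay within the scatter of each other, whereas placing 2,2,2-trifluoroethoxy on the same saturated chain carbon gives an 18-fold lower number from compound 2 to compound 3 (1.25 log units; beyond the scatter) and a 23-fold lower number from compound 1 to compound 3 (1.36 log units; beyond the scatter). No measurement at hand accounts for a drop of this size.

The compounds shown leave open whether the drop goes with the loss of the ring, with the fluorine atoms, or with something else, and a plain ethoxy group would help to separate these possibilities. On these data alone, how an open-chain amine such as dimethylamino or a carboxylic acid would read at this place also remains open.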